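A few compounds are considered here, and "the series" means these few. Any claim that something is new, unique, unknown or untested is made for them only; others in the source may bear on it.

Of the compounds shown here, two of the same core have been measured so far, and they differ only in one halogen on the outer indole ring. Compound 1, `CO[C@@H]1[C@H](N(C)c2ncc(-c3c[nH]c4ccc(F)cc34)s2)C[C@H]2O[C@]1(C)n1c3ccccc3c3c4c(c5c6ccccc6n2c5c31)C(=O)NC4`, gives 510 nM in a functional assay on MV4-11 cells (Homo sapiens) for antiproliferative activity, read by CellTiter-Glo, with a stated time of 72 h; a higher number here means a weaker inhibitor, a lower number a stronger inhibitor. Compound 2, `CO[C@@H]1[C@H](N(C)c2ncc(-c3c[nH]c4ccc(Cl)cc34)s2)C[C@H]2O[C@]1(C)n1c3ccccc3c3c4c(c5c6ccccc6n2c5c31)C(=O)NC4`, gives 420 nM in this assay. The swap of chloro for fluoro produced a 1.2-fold lower number from compound 1 to compound 2 (0.08 log units; within the scatter), so the two numbers are practically the same. Compound 2 thus carries the lower of the two values, but not by a margin that means anything.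

Compound 3, `CO[C@@H]1[C@H](N(C)c2ncc(-c3c[nH]c4ccc(Br)cc34)s2)C[C@H]2O[C@]1(C)n1c3ccccc3c3c4c(c5c6ccccc6n2c5c31)C(=O)NC4`, takes the next step along the same halogen series: bromo in place of chloro on an aromatic carbon. Within the data shown here, the only step that bears on this change is the one from fluoro to chloro, which stayed inside the scatter. On that basis a shift of similar size is expected for the move from chloro to bromo, and no clear direction can be read from the data.

For compound 3 a value of 380 nM is therefore expected in this assay, within a range of 190 nM to 760 nM, which amounts to an expected step of a 1.1-fold lower number from compound 2 to compound 3 (0.04 log units; within the scatter).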

Compound 3, half-maximal inhibitory concentration: 410 nM
Compound 3: the middle estimate sits 1.1-fold (0.03 log units) below what was measured; the range from low to high includes it.
By their numbers in this assay, from the lowest: compounds 3, 2 and 1 (each within the scatter of the next).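

With bromo in place, this position now carries a third halogen, and the swap from chloro again leaves the result in this assay essentially unchanged (a 1.0-fold lower number from compound 2 to compound 3 (0.01 log units; within the scatter)). The earlier comparison covered only fluoro and chloro, whereas the two ends of the series can now be compared directly, and that step also stays within the scatter (a 1.2-fold lower number from compound 1 to compound 3 (0.09 log units; within the scatter)). Among these compounds, then, the choice of halogen on this aromatic carbon makes no clear difference to the number, and none of the three goes against that reading, though no measured finding is available here to explain it.

Going by these compounds, all three compounds carry a halogen at this place, so it remains open whether the number would differ with a plain hydrogen there, or with a different kind of group such as a methoxy group, a nitrile, an amine or a carboxylic acid. On these data alone, it is also open whether the same indifference to the halogen would hold in a different assay, or on a compound with a change elsewhere in the shared core.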